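The source may report more compounds than this note shows. Statements on the series, on what has been measured and on what is new or still open speak of the compounds shown alone.

Compound 1 `Nc1ccc(/C=C2\SC(=O)N(Cc3ccc(F)cc3)C2=O)cc1` and compound 2 `Nc1ccc(/C=C2\SC(=O)N(Cc3ccc(Cl)cc3)C2=O)cc1` share one core; in a functional assay on L1210 cells (Mus musculus) for cytotoxicity, read by cell counting, with a stated time of 2 days (a lower number here means a stronger inhibitor, a higher number a weaker inhibitor), compound 1 gives 24000 nM and compound 2 gives 37000 nM. The step of a 1.5-fold lower number from compound 2 to compound 1 (0.19 log units; within the scatter) is fluoro in place of chloro on an aromatic carbon. Compound 3 `C=C(Br)C(=O)Nc1ccc(/C=C2\SC(=O)N(Cc3cccc(Cl)c3)C2=O)cc1` carries a different core, and the difference between the two cores is not broken down here. In this assay compound 3 gives 3400 nM. Compound 4 `C=C(Br)C(=O)Nc1ccc(/C=C2\SC(=O)N(Cc3cccc(F)c3)C2=O)cc1` is not yet measured; it differs from compound 3 by fluoro in place of chloro on an aromatic carbon, the same kind of change as from compound 2 to compound 1 but not the same: there the fluoro sits para to a large group, here meta to a large group. Compound 4 is expected to show a 1.1-fold lower number from compound 3 to compound 4 (0.05 log units; within the scatter) in this assay, because the earlier step of a 1.5-fold lower number from compound 2 to compound 1 (0.19 log units; within the scatter) stayed within the scatter. The estimate for compound 4 is 3000 nM, between 1200 nM and 8000 nM.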

Compound 4, half-maximal inhibitory concentration: 1200 nM
For compound 4 the middle estimate is 2.5-fold (0.40 log units) above the measured one, within the range that was stated.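

In this assay, fluoro in place of chloro gives a 2.8-fold lower number from compound 3 to compound 4 (0.45 log units; beyond the scatter), and the two steps on the two cores cannot be told apart: the same change on two cores in this assay, a 1.5-fold lower number (0.19 log units; within the scatter) from compound 2 to compound 1 and a 2.8-fold lower number (0.45 log units; beyond the scatter) from compound 3 to compound 4, 1.8-fold (0.26 log units) apart, within the scatter of two such steps The change therefore carries across these two pairs with a comparable size, although only the newer step lies beyond the scatter. Among the compounds shown here, this does not show a general rule: there are only two pairs, they differ in core, and the halogen sits at a different place on the ring in each.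

Open, as far as these compounds go, is whether a methyl, methoxy or trifluoromethyl group in the halogen's place would fit the same reading. Also open, from the compounds shown here alone, is whether the step stays comparable with the halogen at the same place on both cores.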